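Amine substituent swap on the spiro-piperidine nitrogen

This account rests on a few compounds, and the source may have more. Where it says the series, first, only, none or still open, it means among the compounds named here.

Measured so far:
- compound 1 `COc1ccc2[nH]c3c(c2c1)CCNC31CCN(Cc2cccc(F)c2F)CC1`: 13600 nM
- compound 2 `COc1ccc2[nH]c3c(c2c1)CCNC31CCN(C(C)c2ccccc2)CC1`: 20000 nM

Among the measured compounds shown here, in an assay on FRT cells for positive allosteric modulation of Cystic fibrosis transmembrane conductance regulator variant N1303K (Homo sapiens), in the presence of a further agent that is not named here (on this read-out lower numbers stand for an effect already at smaller amounts and higher numbers for an effect only at larger amounts of compound), compound 2 gives 20000 nM; the only comparison point is compound 1, and the pair differ by a 1.5-fold higher number from compound 1 to compound 2 (0.17 log units; within the scatter), so the two cannot be told apart on these numbers. Both sit in the weak range of this assay.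

Compound 3 `COc1ccc2[nH]c3c(c2c1)CCNC31CCN(Cc2ccco2)CC1` is not yet measured. Relative to compound 2 the change is (furan-2-yl)methyl in place of 1-phenylethyl on an amine nitrogen in a ring. For the measured compounds named here, no measured step touches this exchange: the single step known, a 1.5-fold higher number from compound 1 to compound 2 (0.17 log units; within the scatter), concerns a different pair of groups on the same nitrogen and lies within the scatter. With two compounds differing only at this nitrogen and showing no separable effect, the expectation for compound 3 in this assay is a step of about a 1.3-fold lower number from compound 2 to compound 3 (0.12 log units; within the scatter), that is no change beyond the scatter. Compound 3 is therefore estimated at 15000 nM, with a range from 5000 nM to 45000 nM.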

Compound 3, half-maximal effective concentration: 16400 nM
For compound 3 the middle estimate is 1.1-fold (0.04 log units) below the measured one; the measured number falls inside the stated range.
By their numbers in this assay, from the lowest: compounds 1, 3 and 2 (each within the scatter of the next).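

Among the compounds shown here, on an amine nitrogen in a ring, a five-membered aromatic ring with 1 hetero atom now stands in place of the six-membered aromatic rings of the earlier compounds, and in this assay neither a 1.2-fold lower number from compound 2 to compound 3 (0.09 log units; within the scatter) nor a 1.2-fold higher number from compound 1 to compound 3 (0.08 log units; within the scatter) separates from the scatter. This position therefore accepts (furan-2-yl)methyl, with 6 heavy atoms against 8 for 1-phenylethyl and with 1 hydrogen-bond acceptor entering, without a readable shift, and the three compounds remain a single group on this read-out. No supporting data bear on why these exchanges leave the number in place.

Still open, on these data alone, is whether any group on this nitrogen moves the number beyond the scatter, since all three substituents carry an aromatic ring and a plain alkyl chain or a benzyl bearing a carboxylic acid might read differently. The shared core stays constant throughout, so the effect of a hydroxyl in place of the methoxy group also remains unanswered.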